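Nitro in Place of Chloro: From Compound 3 to Compound 4

The source may report more compounds than this note shows. Statements on the series, on what has been measured and on what is new or still open speak of the compounds shown alone.

For the measured compounds named here, the three compounds measured so far share one core and differ only in the aromatic group attached to it. Compound 1 `O=c1nc(-c2ccc3ccccc3c2)ss1` gives 47.2% in an ADME assay on L02 cells (Homo sapiens) for inhibition, read by MTT assay, with a stated time of 48 h, tested at 100 uM; on this read-out lower numbers stand for less inhibition and higher numbers for more inhibition at the one concentration tested (going by the name of the read-out). Compound 2 `O=c1nc(-c2cc(F)c(Cl)nc2Cl)ss1` gives 24.3% in this assay. Compound 3 `O=c1nc(-c2ccccc2Cl)ss1` gives 40.1% in this assay, the second highest of the three numbers: its value sits within the scatter of compound 1, while the gap to compound 2 lies beyond the scatter, with compound 3 the higher of the two.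

Compound 4 `O=c1nc(-c2ccccc2[N+](=O)[O-])ss1` has not yet been measured. It differs from compound 3 in one place: nitro in place of chloro on an aromatic carbon. Going by the values given here, no pair of measured compounds shows this same change, so the data give no direct guide to its size. On the spread of the three values alone, the step from compound 3 to compound 4 in this assay is expected to be small, a number 4.1 percentage points lower from compound 3 to compound 4 (within the scatter), and not clearly beyond the scatter. Compound 4 is estimated at 36%, with a range from 16% to 56%.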

Compound 4, a percentage reported as inhibition, at one concentration (the size of the read-out at that concentration, not a potency): 33%
Beside the measured number, compound 4's estimate is 3 percentage points above it, within the range that was stated.
By their numbers in this assay, from the lowest: compounds 2, 4, 3 and 1 (each within the scatter of the next, the first and the last beyond it).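

Nitro in place of chloro on an aromatic carbon, ortho to a group of 6 heavy atoms, gives a number 7.1 percentage points lower from compound 3 to compound 4 (within the scatter) in this assay, so at this position the read-out does not separate the two groups. For the compounds shown here, this is the first step between compounds that differ in one place; the earlier compounds differed in their whole aromatic group and could not show what one substituent on the ring contributes. Nothing measured here offers an explanation for this step.

The compounds shown leave open whether an amine or a carboxylic acid on this same aromatic carbon would also stay within the scatter of compound 3. They also leave open whether the same exchange would give a step of similar size on the aromatic group of compound 2, which carries chloro.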